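Aromatic Ester Versus Branched Ester: Expectation for Compound 3

The source may report more compounds than this note shows. Statements on the series, on what has been measured and on what is new or still open speak of the compounds shown alone.

Going by the values given here, in a functional assay on A549 cells (Homo sapiens) for cytotoxicity, read by MTT assay, with a stated time of 48 h (a lower number here means a stronger inhibitor, a higher number a weaker inhibitor), compound 2 `C=C1C(=O)O[C@H]2CC3=C[C@H](C/C(C)=C/[C@@H](OC(=O)C(C)(C)CC)[C@H]12)OC3=O` gives 2200 nM, the only actual number so far. Compound 1 `C=C1C(=O)O[C@H]2CC3=C[C@H](C/C(C)=C/[C@@H](OC(=O)c4ccc(C(F)(F)F)cc4)[C@H]12)OC3=O` gives > 10000 nM in this assay, which is a limit of the assay and not a number.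

Compound 3 `C=C1C(=O)O[C@H]2CC3=C[C@H](C/C(C)=C/[C@@H](OC(=O)c4ccncc4)[C@H]12)OC3=O` carries pyridin-4-yl in place of 1,1-dimethylpropyl on a carbonyl carbon. The entering group is an aromatic ring, as is the 4-(trifluoromethyl)phenyl of compound 1, though the two groups are not the same.

Among the compounds with values here, one measured step bears on this: an at least 4.5-fold lower number from compound 1 to compound 2 (0.65 log units; beyond the scatter). Its size is a minimum, and it replaces the aromatic group with the branched chain, the reverse of the present change. A rise of at least modest size is therefore expected in this assay, although a single step makes this uncertain. The expected step is a 3.2-fold higher number from compound 2 to compound 3 (0.50 log units; beyond the scatter). For compound 3, the estimated value is 7000 nM, with an expected range of 2500 nM to 20000 nM.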

Compound 3, half-maximal inhibitory concentration: > 10000 nM
Compound 3 gave a limit, no number; the forecaster's own chance of this, stated with the estimate: 40%; middle value at least 1.4-fold (0.15 log units) from the limit.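

In this assay a second aromatic group on this carbonyl carbon gives no number: the change shows an at least 4.5-fold higher number from compound 2 to compound 3 (0.65 log units; beyond the scatter) as a minimum size, resting on a limit of the assay and not on a number for compound 3. Pyridin-4-yl thus goes the same way as the 4-(trifluoromethyl)phenyl of compound 1, so among the compounds shown the loss against the 1,1-dimethylpropyl of compound 2 is not tied to one aromatic group. The step between compound 1 and compound 3 cannot be read, and the two sit together at the ceiling: the limit of > 10000 nM in this assay, at which 2 of the 3 values shown sit.

Going by these compounds, how far either aromatic ester lies beyond compound 2 stays open. Also open, on these data alone, is whether a longer branched chain, an amine or a carboxylic acid on this carbonyl carbon would keep a measurable number.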